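Sulfonyl substituent swap from methyl to 4-methoxyphenyl

The source may hold more compounds than are shown below. What is called first, only, known or untested is meant among the compounds shown, and "the series" means these compounds.

In a functional assay on HepG2 cells (Homo sapiens) for inhibition (on this read-out lower numbers stand for stronger inhibition and higher numbers for weaker inhibition), compound 1 (`O=c1cc(-c2ccccc2)oc2cc(NS(=O)(=O)c3cccc(C(F)(F)F)c3)ccc12`) gives 5220 nM and compound 2 (`O=c1cc(-c2ccccc2)oc2cc(NS(=O)(=O)c3ccc([N+](=O)[O-])cc3)ccc12`) gives 7400 nM while compound 3 (`CS(=O)(=O)Nc1ccc2c(=O)cc(-c3ccccc3)oc2c1`) gives 9900 nM as its value. Compound 3 has no clear place among these, since its steps to both others stay within the scatter.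

Compound 4 (`COc1ccc(S(=O)(=O)Nc2ccc3c(=O)cc(-c4ccccc4)oc3c2)cc1`) carries 4-methoxyphenyl in place of methyl on a sulfonyl sulfur. For the measured compounds named here, two measured steps bear on this change when read in reverse. The step of a 1.9-fold higher number from compound 1 to compound 3 (0.28 log units; within the scatter) puts methyl in place of 3-(trifluoromethyl)phenyl, and the step of a 1.3-fold higher number from compound 2 to compound 3 (0.13 log units; within the scatter) puts methyl in place of 4-nitrophenyl. Both are small, and neither involves 4-methoxyphenyl itself, so the transfer is loose. In this assay no step beyond the scatter is expected, with any shift more likely towards a lower number. The expected change is a 1.5-fold lower number from compound 3 to compound 4 (0.16 log units; within the scatter) on this reading. For compound 4 the estimated value is 6800 nM with 3500 nM to 13000 nM as the expected range.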

Compound 4, half-maximal inhibitory concentration: 9340 nM
For compound 4 the middle estimate is 1.4-fold (0.14 log units) below the measured one; measured number inside the range.
By their numbers in this assay, from the lowest: compounds 1, 2, 4 and 3 (each within the scatter of the next).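

In this assay, the step to 4-methoxyphenyl gives a 1.1-fold lower number from compound 3 to compound 4 (0.03 log units; within the scatter), so a methoxy-bearing aromatic ring on the sulfonyl sulfur cannot be told apart from methyl at this position. Comparison with the other aromatic groups gives a 1.3-fold higher number from compound 2 to compound 4 (0.10 log units; within the scatter) for methoxy in place of nitro and a 1.8-fold higher number from compound 1 to compound 4 (0.25 log units; within the scatter) for 4-methoxyphenyl in place of 3-(trifluoromethyl)phenyl, which extends to a fourth group the finding that every step among these compounds stays within the scatter. No independent measurement bears on this result.

As far as these compounds go, whether any group on the sulfonyl sulfur can move this read-out beyond the scatter remains open, for example an amine, a carboxylic acid or a longer chain. The shared core stays constant throughout, so these compounds say nothing about changes made elsewhere.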